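Carboxy analogue of compound 1: cytotoxicity outlook

The source may report more compounds than this note shows. Statements on the series, on what has been measured and on what is new or still open speak of the compounds shown alone.

Measured so far:
compound 1, `O=C(/C=C/c1ccc2c(c1)B(O)OC2)c1ccccc1`: 6100 nM
compound 2, `COCOc1ccccc1C(=O)/C=C/c1ccc2c(c1)B(O)OC2`: 10200 nM
compound 3, `COCOc1cccc(C(=O)/C=C/c2ccc3c(c2)B(O)OC3)c1`: 13300 nM

In a functional assay on HCT-116 cells (Homo sapiens) for cytotoxicity, read by MTT assay, with a stated time of 48 h (on this read-out higher numbers stand for weaker inhibition and lower numbers for stronger inhibition), compound 1 gives the lowest number of the three. The two steps that bear on the series are a 1.7-fold higher number from compound 1 to compound 2 (0.22 log units; within the scatter) and a 2.2-fold higher number from compound 1 to compound 3 (0.34 log units; beyond the scatter), each from methoxymethoxy in place of hydrogen on an aromatic carbon. Compound 4, `O=C(O)c1ccc(C(=O)/C=C/c2ccc3c(c2)B(O)OC3)cc1`, is not yet measured; it differs from compound 1 by carboxy in place of hydrogen on an aromatic carbon. Going by the values given here, no measured step puts a carboxy group on the shared core, so the methoxymethoxy steps are the only guide; both point to a small upward shift in the number, one within the scatter and one just beyond it. For compound 4 a modest upward step or none beyond the scatter is expected, estimated as a 1.4-fold higher number from compound 1 to compound 4 (0.14 log units; within the scatter). Compound 4 is thus expected at 8500 nM, within 3500 nM to 22000 nM.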

Compound 4, half-maximal inhibitory concentration: > 100000 nM
Compound 4 gave a limit, no number; the forecaster's own chance of this, stated with the estimate: 5%; at least 11-fold (1.07 log units) between middle value and limit.
By their numbers in this assay, from the lowest: compounds 1, 2 and 3 (each within the scatter of the next, the first and the last beyond it). At a limit, above all of these: compound 4.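

In this assay, compound 4 gives a limit and not a number: the limit of > 100000 nM in this assay, at which 1 of the 4 values shown sits. Carboxy in place of hydrogen on an aromatic carbon, para to a large group, gives an at least 16-fold higher number from compound 1 to compound 4 (1.21 log units; beyond the scatter), so a single change on this ring can take the number far up. The methoxymethoxy changes showed nothing of this size, with a 1.7-fold higher number from compound 1 to compound 2 (0.22 log units; within the scatter) and a 2.2-fold higher number from compound 1 to compound 3 (0.34 log units; beyond the scatter).

Open, as far as these compounds go, is whether this step belongs to carboxy itself or to carboxy at this place. The compounds shown include neither a methyl ester or an amine at this position nor carboxy elsewhere on the ring.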